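The compounds below may be only part of what the source reports. "The series", "measured", "known", "first", "only" and "open" are said of these compounds alone.

Series on the shared core of compound 1 `CC[S+]([O-])CCCCN=C=S`, which in a functional assay on MCF7 cells (Homo sapiens) for cytotoxicity, read by MTT assay, with a stated time of 72 h (on this read-out lower numbers stand for stronger inhibition and higher numbers for weaker inhibition), gives 8260 nM. Compound 2 `CC(C)C[S+]([O-])CCCCN=C=S` gives 3660 nM, and the step of a 2.3-fold lower number from compound 1 to compound 2 (0.35 log units; beyond the scatter) is the only one measured so far. Compound 2 therefore holds the lowest of the two numbers, with compound 1 the nearest at a higher number. Compound 3 `[O-][S+](CCCCN=C=S)Cc1cccs1` carries thiophen-2-yl in place of isopropyl on a saturated chain carbon bound to a sulfur. Within the data shown here, only the step from methyl to isopropyl bears on this change; it was modest and beyond the scatter, and a further modest lowering is expected, a 1.5-fold lower number from compound 2 to compound 3 (0.17 log units; within the scatter). For compound 3 the estimate is 2500 nM, within 900 nM to 7000 nM.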

Compound 3, half-maximal inhibitory concentration: 4140 nM
Compound 3: middle estimate off by 1.7-fold (0.22 log units), on the low side; measured number inside the range.
By their numbers in this assay, from the lowest: compounds 2, 3 and 1 (each within the scatter of the next, the first and the last beyond it).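

At this saturated chain carbon bound to a sulfur, thiophen-2-yl in place of isopropyl brings a five-membered aromatic ring without a separable change in the number (a 1.1-fold higher number from compound 2 to compound 3 (0.05 log units; within the scatter)). Against the methyl-bearing parent, the picture differs from that of isopropyl, as the ring stays inside the scatter (a 2.0-fold lower number from compound 1 to compound 3 (0.30 log units; within the scatter)). Nothing measured alongside these numbers accounts for either step.

From the compounds shown here alone, whether an amine, a carboxylic acid or a longer chain on this carbon would move the number beyond the scatter from compound 2 remains open.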